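Swapping the Side Group for a Tetrazole

A few compounds are considered here, and "the series" means these few. Any claim that something is new, unique, unknown or untested is made for them only; others in the source may bear on it.

Measured in a functional assay on HUVEC cells (Homo sapiens), read by scintillation counting and thymidine incorporation, with a stated time of 24 h; a higher number here means a weaker inhibitor, a lower number a stronger inhibitor:
- compound 1 `CCC(C)n1ncn(-c2ccc(N3CCN(c4ccc(OC[C@@H]5CO[C@@](CN6CCN(C)CC6)(c6ccc(Cl)cc6Cl)O5)cc4)CC3)cc2)c1=O`: 396 nM
- compound 2 `CCC(C)n1ncn(-c2ccc(N3CCN(c4ccc(OC[C@@H]5CO[C@@](Cn6cc(C(F)(F)F)nc6C)(c6ccc(Cl)cc6Cl)O5)cc4)CC3)cc2)c1=O`: 441 nM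

Compound 2, at 441 nM, stands level with compound 1 within the scatter. Compound 3 `CCC(C)n1ncn(-c2ccc(N3CCN(c4ccc(OC[C@@H]5CO[C@@](Cn6cnnn6)(c6ccc(Cl)cc6Cl)O5)cc4)CC3)cc2)c1=O` carries 1H-tetrazol-1-yl in place of 2-methyl-4-(trifluoromethyl)-1H-imidazol-1-yl on a saturated chain carbon bound to a saturated ring carbon. Within the data shown here, only one measured step bears on this place: a 1.1-fold higher number from compound 1 to compound 2 (0.05 log units; within the scatter), which lies within the scatter. That single step is thin evidence, and no tetrazole has yet been measured. No shift beyond the scatter is therefore expected in this assay, in either direction. The expected step is a 1.1-fold lower number from compound 2 to compound 3 (0.02 log units; within the scatter). Compound 3 is estimated at 420 nM, with an expected range of 170 nM to 1000 nM.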

Compound 3, half-maximal inhibitory concentration: 73 nM
For compound 3 the middle estimate is 5.8-fold (0.76 log units) above the measured one; the measured number lies below the stated range.
By their numbers in this assay, from the lowest: compound 3; then compounds 1 and 2 (each within the scatter of the next).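

In this assay the group on this saturated chain carbon proves able to move the number: 1H-tetrazol-1-yl gives a 6.0-fold lower number from compound 2 to compound 3 (0.78 log units; beyond the scatter) and a 5.4-fold lower number from compound 1 to compound 3 (0.73 log units; beyond the scatter) in the same assay. The earlier exchange of 4-methylpiperazin-1-yl for 2-methyl-4-(trifluoromethyl)-1H-imidazol-1-yl had stayed within the scatter, so this position is not indifferent to what it carries. No measurement at hand accounts for the difference.

As far as these compounds go, how a 1H-1,2,4-triazol-1-yl or a carboxylic acid on the same carbon would compare stays open. A single tetrazole also cannot show whether the ring's four hetero atoms matter.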